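Homologating the Azetidine Amide in a PFKFB3 Inhibitor Series

The source may hold more compounds than are shown below. What is called first, only, known or untested is meant among the compounds shown, and "the series" means these compounds.

Compound 1 `CN1CC(NC(=O)c2ccncc2Nc2cc(-c3ccc4ccn(C)c4c3)c3nccnc3c2)C1` is the reference point here: in an assay for inhibition of 6-phosphofructo-2-kinase/fructose-2,6-bisphosphatase 3 (Homo sapiens), read by ADP-Glo, with a stated time of 2 h (on this read-out lower numbers stand for stronger inhibition and higher numbers for weaker inhibition), compound 1 gives 30 nM. Compound 2 `CC(=O)N1CC(NC(=O)c2ccncc2Nc2cc(-c3ccc4ccn(C)c4c3)c3nccnc3c2)C1` keeps the same core and differs only in that an acetyl replaces the methyl on the ring amine nitrogen; in this assay compound 2 gives 73 nM. For the measured compounds named here, that single change produced a 2.4-fold higher number from compound 1 to compound 2 (0.39 log units; beyond the scatter), so compound 2 stands at the higher of the two numbers measured so far, with compound 1 as its only neighbour.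

Compound 3 `CC(=O)N1CC(CNC(=O)c2ccncc2Nc2cc(-c3ccc4ccn(C)c4c3)c3nccnc3c2)C1` has not yet been measured. Relative to compound 2 the change is (1-acetylazetidin-3-yl)methyl in place of 1-acetylazetidin-3-yl on an amide-type nitrogen, so the acetylazetidine now reaches the amide nitrogen through a methyl rather than directly. Going by the values given here, no measured step addresses this kind of change: the only step available, the acetyl for methyl swap from compound 1 to compound 2, concerns a different position and was modest in size. With nothing comparable to lean on, he expects the step to compound 3 to be small, a 1.4-fold higher number from compound 2 to compound 3 (0.14 log units; within the scatter), and quite possibly within the scatter. His estimate for compound 3 in this assay is 100 nM, within a range from 35 nM to 300 nM.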

Compound 3, half-maximal inhibitory concentration in the 6-phosphofructo-2-kinase/fructose-2,6-bisphosphatase 3 assay: 137 nM
For compound 3 the middle estimate is 1.4-fold (0.14 log units) below the measured one, within the range that was stated.
By their numbers in the 6-phosphofructo-2-kinase/fructose-2,6-bisphosphatase 3 assay, from the lowest: compound 1; then compounds 2 and 3 (each within the scatter of the next).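

In the 6-phosphofructo-2-kinase/fructose-2,6-bisphosphatase 3 assay compound 3 gives 137 nM; replacing 1-acetylazetidin-3-yl with (1-acetylazetidin-3-yl)methyl on the amide-type nitrogen gives a 1.9-fold higher number from compound 2 to compound 3 (0.27 log units; within the scatter), so this position tolerates the added methyl without a change that can be told apart from repeat measurements. In a physicochemical assay for solubility, read by spectrophotometry, measured as kinetic solubility, at pH 8, tested at 500 uM (on this read-out lower numbers stand for lower solubility and higher numbers for higher solubility), compound 2 gives 244 ug/mL and compound 3 gives 252 ug/mL, and the same change gives a 1.0-fold higher number from compound 2 to compound 3 (0.01 log units; within the scatter), which also lies within the scatter. The wider comparison in the 6-phosphofructo-2-kinase/fructose-2,6-bisphosphatase 3 assay is a 4.6-fold higher number from compound 1 to compound 3 (0.66 log units; beyond the scatter), which is beyond the scatter, so compound 1 remains separated from both compound 2 and compound 3 while those two stay unresolved from each other. No supporting evidence bears on why either read-out responds in this way.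

Going by these compounds, the added methyl appears here only together with the acetyl on the azetidine, so it remains open whether the same change would be as quiet with the ring nitrogen carrying a methyl, as in compound 1. On these data alone, it is also open how far this tolerance extends, for instance to a longer chain reaching the amide-type nitrogen or to a piperidine in place of the azetidine.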